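Trifluoromethoxy in Place of Trifluoromethyl: Compound 4 Forecast

The source may hold more compounds than are shown below. What is called first, only, known or untested is meant among the compounds shown, and "the series" means these compounds.

In a functional assay on MCF7 cells (Homo sapiens) for cytotoxicity, read by MTT assay, with a stated time of 72 h (on this read-out higher numbers stand for weaker inhibition and lower numbers for stronger inhibition), compound 3 `Cc1cc(=O)n(-c2ccccc2C(F)(F)F)nc1C(=O)Nc1ccc(Oc2ncnc3sccc23)c(F)c1` gives 13800 nM. Its two companions sit close by: compound 1 `Cc1cc(=O)n(-c2ccccc2OC(F)(F)F)nc1C(=O)Nc1ccc(Oc2ncnc3ccsc23)c(F)c1` gives 11500 nM and compound 2 `Cc1cc(=O)n(-c2ccccc2OC(F)(F)F)nc1C(=O)Nc1ccc(Oc2ncnc3sccc23)cc1` gives 11000 nM in this assay, each within the usual scatter of the figure for compound 3, so no order among the three can be claimed. Compound 4 `Cc1cc(=O)n(-c2ccccc2OC(F)(F)F)nc1C(=O)Nc1ccc(Oc2ncnc3sccc23)c(F)c1` differs from compound 3 in one place: trifluoromethoxy in place of trifluoromethyl on an aromatic carbon. Among the compounds with values here, no measured pair in this set isolates that exchange, so its effect remains unknown here. Because compound 1 gives 11500 nM, compound 2 gives 11000 nM and compound 3 gives 13800 nM, all similar figures, the step of a 1.2-fold lower number from compound 3 to compound 4 (0.06 log units; within the scatter) is expected to be none beyond the scatter. Compound 4 is estimated at 12000 nM, with a range from 6000 nM to 24000 nM.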

Compound 4, half-maximal inhibitory concentration: > 40000 nM
Compound 4 ended at the assay's limit; the forecaster's own chance of this, stated with the estimate: 5%; at least 3.3-fold (0.52 log units) between middle value and limit.
By their numbers in this assay, from the lowest: compounds 2, 1 and 3 (each within the scatter of the next). At a limit, above all of these: compound 4.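

In this assay compound 4 stands at a limit and not at a number: the limit of > 40000 nM in this assay, at which 1 of the 4 values shown sits. On this aromatic carbon, ortho to a large group, trifluoromethoxy in place of trifluoromethyl gives an at least 2.8-fold higher number from compound 3 to compound 4 (0.46 log units; beyond the scatter), a sensitivity the closely grouped earlier compounds did not show. Two other single changes also separate compound 4 from its neighbours: fluoro in place of hydrogen gives an at least 3.6-fold higher number from compound 2 to compound 4 (0.56 log units; beyond the scatter), and the exchange of the group on the oxygen gives an at least 3.4-fold higher number from compound 1 to compound 4 (0.54 log units; beyond the scatter).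

Going by these compounds, how far compound 4 lies past the limit stays unknown, so these steps have no upper size. On these data alone, whether a methoxy group or an amine on this aromatic carbon would stay with compound 3 or follow compound 4 remains open.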